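The source may hold more compounds than are shown below. What is called first, only, known or untested is meant among the compounds shown, and "the series" means these compounds.

Measured compounds:
Compound 1 `O=C(N/N=C/c1ccc(O)cc1O)c1ccc(-c2nc3ccccc3s2)cc1`: 5580 nM
Compound 2 `COc1cccc(/C=N/NC(=O)c2ccc(-c3nc4ccccc4s3)cc2)c1`: 11100 nM

Both numbers come from an assay on isolated protein for inhibition of Maltase-glucoamylase (Homo sapiens), with a stated time of 15 min; a higher number here means a weaker inhibitor, a lower number a stronger inhibitor. Compound 1 and compound 2 share a core and differ only in the aromatic ring attached to the carbon carrying the double bond to nitrogen. For the measured compounds named here, the single step recorded, a 2.0-fold higher number from compound 1 to compound 2 (0.30 log units; within the scatter), stays within the scatter of this kind of measurement, so the two values cannot be told apart; compound 1 stands within the scatter of compound 2, the only other compound measured.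

Compound 3 `COc1cc(/C=N/NC(=O)c2ccc(-c3nc4ccccc4s3)cc2)ccc1O` has not yet been measured in this assay. It keeps the core of compound 1 and changes the same ring: 4-hydroxy-3-methoxyphenyl in place of 2,4-dihydroxyphenyl on a carbon with a double bond to nitrogen. Going by the values given here, the only step that bears on this change is a 2.0-fold higher number from compound 1 to compound 2 (0.30 log units; within the scatter), which exchanged the same 2,4-dihydroxyphenyl for a 3-methoxyphenyl and moved the number by less than the scatter. The new ring keeps a hydroxy group and adds the methoxy seen in compound 2, so no step beyond the scatter is expected in this assay. The estimate for compound 3 is therefore 7500 nM, with a range from 3000 nM to 18000 nM, which means an expected step of a 1.3-fold higher number from compound 1 to compound 3 (0.13 log units; within the scatter).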

Compound 3, half-maximal inhibitory concentration: 53300 nM
Compound 3: middle estimate off by 7.1-fold (0.85 log units), on the low side; the measured number lies above the stated range.
By their numbers in this assay, from the lowest: compounds 1 and 2 (each within the scatter of the next); then compound 3.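

In this assay, for the compounds shown here, the ring on this carbon with a double bond to nitrogen matters more than the first pair of compounds suggested: 4-hydroxy-3-methoxyphenyl in place of 2,4-dihydroxyphenyl gives a 9.6-fold higher number from compound 1 to compound 3 (0.98 log units; beyond the scatter). The second step isolates a single change, hydroxy in place of hydrogen on an aromatic carbon, and it gives a 4.8-fold higher number from compound 2 to compound 3 (0.68 log units; beyond the scatter), so adding this hydroxy to the 3-methoxyphenyl ring makes the inhibitor weaker rather than stronger. Having hydroxy groups on the ring therefore does not by itself set the order, since compound 1, with its 2,4-dihydroxyphenyl, and compound 2, with its 3-methoxyphenyl, lie within the scatter of each other, while compound 3 stands apart from both.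

Nothing available gives a reason for this loss. From the compounds shown here alone, it remains open whether the loss comes from the hydroxy alone or only from its combination with the methoxy, which a plain 4-hydroxyphenyl ring could help to separate, and whether an amine or a carboxylic acid on this ring would give a stronger or a weaker inhibitor.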